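The source may report more compounds than this note shows. Statements on the series, on what has been measured and on what is new or still open speak of the compounds shown alone.

Working notes on the series in a functional assay on SGC-7901 cells (Homo sapiens) for antiproliferative activity, read by MTT assay, with a stated time of 72 h; a higher number here means a weaker inhibitor, a lower number a stronger inhibitor.

Three compounds share one core and carry a trimethoxyphenyl group on it, differing only in the aryl group on the fused ring. Compound 1 `COc1cc(-n2cnc3ccc(-c4cccc(F)c4)cc32)cc(OC)c1OC` gives 2490 nM in this assay. Compound 2 `COc1ccc(-c2ccc3ncn(-c4cc(OC)c(OC)c(OC)c4)c3c2)cc1F` gives 430 nM, the step being a 5.8-fold lower number from compound 1 to compound 2 (0.76 log units; beyond the scatter). Compound 3 `COc1cc(-n2cnc3ccc(-c4cccc(C)c4)cc32)cc(OC)c1OC` gives 1240 nM, the second highest of the three numbers. Its nearest neighbour is compound 1, with a 2.0-fold lower number from compound 1 to compound 3 (0.30 log units; within the scatter); the furthest is compound 2, with a 2.9-fold higher number from compound 2 to compound 3 (0.46 log units; beyond the scatter).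

Compound 4 `COc1cc(-n2cnc3ccc(-c4ccc(F)cc4)cc32)cc(OC)c1OC` is not yet measured. It differs from compound 3 in one place: 4-fluorophenyl in place of 3-methylphenyl on an aromatic carbon. The change is on an aromatic carbon meta to a fused ring and para to a fused ring.

The step that bears most directly on this change is the methyl-for-fluoro exchange, a 2.0-fold lower number from compound 1 to compound 3 (0.30 log units; within the scatter), which stayed within the scatter. The larger steps involve the methoxy-bearing aryl group of compound 2 and do not concern compound 4. No measured step separates a fluoro on the aryl group in the two places shown here, so the weight rests on compound 1 and compound 3 alone.

Compound 4 is therefore expected to sit close to compound 3, with a 1.5-fold higher number from compound 3 to compound 4 (0.16 log units; within the scatter) and an estimated value of 1800 nM, range 700 nM to 4500 nM.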

Compound 4, half-maximal inhibitory concentration: 3500 nM
For compound 4 the middle estimate is 1.9-fold (0.29 log units) below the measured one, and the stated range covers the measured number.
By their numbers in this assay, from the lowest: compound 2; then compounds 3, 1 and 4 (each within the scatter of the next, the first and the last beyond it).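

In this assay, the step to the 4-fluorophenyl group from the 3-methylphenyl group is a 2.8-fold higher number from compound 3 to compound 4 (0.45 log units; beyond the scatter), while the step from the 3-fluorophenyl group is a 1.4-fold higher number from compound 1 to compound 4 (0.15 log units; within the scatter). Moving the fluoro on the aryl group therefore gives no change that can be separated from the scatter in this pair, and compound 3 differs from compound 4 even though it does not stand apart from compound 1. The 3-fluoro-4-methoxyphenyl group of compound 2 now stands apart from all three other aryl groups, with an 8.1-fold higher number from compound 2 to compound 4 (0.91 log units; beyond the scatter) as the widest step in the series. The data shown offer no independent measurement that would explain any of these differences.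

The compounds shown do not tell whether the low number of compound 2 comes from the methoxy alone or from the methoxy and fluoro together, and a 4-methoxyphenyl group would separate the two. From the compounds shown here alone, how an aryl group bearing an amine or a carboxylic acid would read in this assay also remains open, as does the effect of moving the methyl on the aryl group of compound 3.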